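The source may hold more compounds than are shown below. What is called first, only, known or untested is meant among the compounds shown, and "the series" means these compounds.

Measured so far:
compound 1, `COc1cc2nc(N3CCC(N4CCCC4)CC3)nc(NCc3ccccc3)c2cc1OC`, gives < 0% in an in vitro assay on B300-19 cells for displacement of a labelled ligand from C-C chemokine receptor type 4 (Homo sapiens), tested at 1 uM (on this read-out lower numbers stand for less inhibition and higher numbers for more inhibition at the one concentration tested (going by the name of the read-out)), a limit of the assay rather than a number.
compound 2, `COc1cc2nc(NC(C)C)nc(NC3CCCCCC3)c2cc1OC`, gives 6% in this assay.

For the measured compounds named here, compound 2 thus holds the only plain number in this assay, and that number sits low; the other result is the limit of < 0% in this assay, at which 1 of the 2 values shown sits. Compound 3, `COc1cc2nc(NCCCN3CCCC3=O)nc(NC3CCCCCC3)c2cc1OC`, is not yet measured. It differs from compound 2 in one place: 3-(2-oxopyrrolidin-1-yl)propyl in place of isopropyl on a nitrogen on an aromatic ring. Going by the values given here, since no pair of measured compounds differing in one place is available, there is no measured step to lean on for this change. With compound 2 showing 6%, the expectation for compound 3 is a small move, if any, staying close to the scatter, so the step of a number 4 percentage points higher from compound 2 to compound 3 (within the scatter) is estimated to be slight. Compound 3 is therefore expected to give about 10% in this assay, within 0% to 30%.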

Compound 3, a percentage reported as inhibition, at one concentration (the size of the read-out at that concentration, not a potency): 8%
Compound 3: middle estimate off by 2 percentage points, on the high side, and the stated range covers the measured number.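

On the nitrogen on an aromatic ring, the 3-carbon isopropyl can be replaced by the 9-heavy-atom 3-(2-oxopyrrolidin-1-yl)propyl, with its five-membered non-aromatic ring and hydrogen-bond acceptor, and this assay gives a number 2 percentage points higher from compound 2 to compound 3 (within the scatter). This first measured step at this position shows that, at the one concentration tested, the much bigger group brings no difference beyond the scatter. The result of compound 1 is a limit of the assay and not a number: the limit of < 0% in this assay, at which 1 of the 3 values shown sits.

On these data alone, whether an amine or a carboxylic acid in place of the 2-oxopyrrolidin-1-yl group, or a longer chain, would shift the read-out beyond the scatter stays open. The other substituents on the shared core are the same in compound 2 and compound 3, so this pair says nothing about what they contribute.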